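A few compounds are considered here, and "the series" means these few. Any claim that something is new, unique, unknown or untested is made for them only; others in the source may bear on it.

Compound 3 `NC(=O)c1cccc(CNc2ccc(CCC(=O)O)cc2)c1` carries a carbamoyl group where compound 1 `O=C(O)CCc1ccc(NCc2cccc(Br)c2)cc1` has bromo and compound 2 `O=C(O)CCc1ccc(NCc2ccccc2)cc1` has hydrogen. In a functional assay on CHO cells for agonist activity at Free fatty acid receptor 1 (Homo sapiens), read by reporter gene assay (on this read-out higher numbers stand for larger maximal responses and lower numbers for smaller maximal responses), compound 1 gives 120% and compound 2 gives 144%, while compound 3 gives 18%, the lowest of the three values by a wide margin. The two steps that lead to it, a number 102 percentage points lower from compound 1 to compound 3 (beyond the scatter) and a number 126 percentage points lower from compound 2 to compound 3 (beyond the scatter), are both large drops, and the step of a number 24 percentage points higher from compound 1 to compound 2 (beyond the scatter) is modest by comparison.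

Compound 4 `CS(=O)(=O)Nc1cccc(CNc2ccc(CCC(=O)O)cc2)c1` differs from compound 3 in one place: methanesulfonamido in place of carbamoyl on an aromatic carbon. Among the measured compounds shown here, no measured step shows methanesulfonamido entering, so the only guide is that carbamoyl at this position is tied to the large drops seen in compound 3. Removing it might recover part of that loss, but the incoming group is of a similar kind, so a return to the level of compound 1 or compound 2 is not expected. In this assay compound 4 is therefore estimated at 40%, within 10% to 95%, an expected step of a number 22 percentage points higher from compound 3 to compound 4 (beyond the scatter).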

Compound 4, largest response reached (reported as percent of maximum), in percent of the reference or control that the assay uses: 9%
The estimate for compound 4 lay 31 percentage points above the measured number; measured number below the stated range.
By their numbers in this assay, from the lowest: compounds 4 and 3 (each within the scatter of the next); then compound 1; then compound 2.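

In this assay, putting methanesulfonamido in place of carbamoyl on this aromatic carbon gives a number 9 percentage points lower from compound 3 to compound 4 (within the scatter) and so the two groups cannot be told apart at this position, although they differ in size and in their count of hydrogen-bond acceptors. The low response is thus no longer tied to carbamoyl alone: methanesulfonamido in place of hydrogen gives a number 135 percentage points lower from compound 2 to compound 4 (beyond the scatter) and methanesulfonamido in place of bromo gives a number 111 percentage points lower from compound 1 to compound 4 (beyond the scatter) and these drops are as large as those seen with carbamoyl. Nothing available explains why these two groups give so low a response while hydrogen and bromo do not. From the compounds shown here alone, whether a smaller group here, such as methyl, methoxy or hydroxy, would keep the response of compound 2 stays open. So does whether an amine or a carboxylic acid at this position would behave like carbamoyl and methanesulfonamido.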